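The source may report more compounds than this note shows. Statements on the series, on what has been measured and on what is new or still open speak of the compounds shown alone.

In a functional assay on HepG2 cells (Homo sapiens) for antiproliferative activity, read by MTT assay, with a stated time of 24 h (on this read-out higher numbers stand for weaker inhibition and lower numbers for stronger inhibition), compound 1 (`c1ccc(CSc2nnc(-c3ccc4c(c3)OCCO4)n2-c2ccccc2)cc1`) gives 5960 nM as the reference point, compound 2 (`Cc1ccc(CSc2nnc(-c3ccc4c(c3)OCCO4)n2-c2ccccc2)cc1`) gives 56800 nM as the highest number, and compound 3 (`Fc1cccc(F)c1CSc1nnc(-c2ccc3c(c2)OCCO3)n1-c1ccccc1`) gives 2070 nM as the lowest of the three.

Compound 4 (`Brc1cccc(CSc2nnc(-c3ccc4c(c3)OCCO4)n2-c2ccccc2)c1`) comes next. The change from compound 3 is 3-bromophenyl in place of 2,6-difluorophenyl on a saturated chain carbon bound to a sulfur and reads as 3-bromophenyl in place of 2,6-difluorophenyl on a saturated chain carbon bound to a sulfur.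

Going by the values given here, three measured steps bear on it: a modest one (a 2.9-fold lower number from compound 1 to compound 3 (0.46 log units; beyond the scatter)), a modest one in the opposite direction (a 9.5-fold higher number from compound 1 to compound 2 (0.98 log units; beyond the scatter)) and a large one (a 27-fold lower number from compound 2 to compound 3 (1.44 log units; beyond the scatter)). Among the compounds with values here, no measured compound carries bromine, so the direction is not settled by the data. Compound 4 gives up the 2,6-difluorophenyl of compound 3, so a number near compound 1 at 5960 nM is expected, while compound 2 at 56800 nM keeps the upper side open.

The expected step in this assay (a 3.1-fold higher number from compound 3 to compound 4 (0.50 log units; beyond the scatter)) is a modest rise. The value estimated for compound 4 is 6500 nM (expected range 1800 nM to 25000 nM).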

Compound 4, half-maximal inhibitory concentration: 5210 nM
Estimate against measurement, compound 4: 1.2-fold (0.10 log units) above, within the range that was stated.
By their numbers in this assay, from the lowest: compound 3; then compounds 4 and 1 (each within the scatter of the next); then compound 2.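

In this assay, putting a bromine on the phenyl leaves the number within the scatter (a 1.1-fold lower number from compound 1 to compound 4 (0.06 log units; within the scatter)), so a single added atom on this phenyl does not by itself move the read-out. The rise seen with 4-methylphenyl therefore does not extend to 3-bromophenyl (an 11-fold lower number from compound 2 to compound 4 (1.04 log units; beyond the scatter)), although these two groups differ in both substituent and its printed number, while 2,6-difluorophenyl keeps the lower number (a 2.5-fold higher number from compound 3 to compound 4 (0.40 log units; beyond the scatter)). No measurement on hand gives a cause for these steps.

Still open, from the compounds shown here alone, is whether the large gap between 4-methylphenyl and 3-bromophenyl follows the substituent or its place on the ring. Also open, going by these compounds, is how an amine or a carboxylic acid on this phenyl, or a longer chain to the sulfur, would read.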